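The source may report more compounds than this note shows. Statements on the series, on what has been measured and on what is new or still open speak of the compounds shown alone.

Compound 1 `CCCCCCn1ccc2cc(/C(C)=C/C(=O)Nc3ccccc3OCCCC(=O)O)ccc21`: 77 nM
Compound 2 `CCCCC(CCCC)n1ccc2cc(/C(C)=C/C(=O)Nc3ccccc3OCCCC(=O)O)ccc21`: 21 nM
Compound 3 `CCCCCC(CCCCC)n1ccc2cc(/C(C)=C/C(=O)Nc3ccccc3OCCCC(=O)O)ccc21`: 25 nM

These three share a core and differ only in the group on the aromatic nitrogen, all measured in an assay on Prostate gland for inhibition of steroid 5-alpha-reductase (Rattus norvegicus); on this read-out higher numbers stand for weaker inhibition and lower numbers for stronger inhibition. Compound 3 holds the second highest number; against compound 2 it differs by a 1.2-fold higher number from compound 2 to compound 3 (0.08 log units; within the scatter), while against compound 1 it stands at a 3.1-fold lower number from compound 1 to compound 3 (0.49 log units; beyond the scatter). Compound 4 `COc1ccc(Cn2ccc3cc(/C(C)=C/C(=O)Nc4ccccc4OCCCC(=O)O)ccc32)cc1` is not yet measured. It differs from compound 3 in that (4-methoxybenzyl in place of 1-pentylhexyl on an aromatic nitrogen). Going by the values given here, the step of a 3.7-fold lower number from compound 1 to compound 2 (0.56 log units; beyond the scatter) and the step of a 3.1-fold lower number from compound 1 to compound 3 (0.49 log units; beyond the scatter) bear on it, both modest; no measured step brings in an aromatic ring at this position, so the effect of the 4-methoxybenzyl group is unknown. A step back toward the level of compound 1 is expected, giving a 2.4-fold higher number from compound 3 to compound 4 (0.38 log units; beyond the scatter). Compound 4 is therefore estimated at 60 nM, between 20 nM and 200 nM.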

Compound 4, half-maximal inhibitory concentration: 480 nM
The estimate for compound 4 lay 8.0-fold (0.90 log units) below the measured number; the whole stated range lies below it.
By their numbers in this assay, from the lowest: compounds 2 and 3 (each within the scatter of the next); then compound 1; then compound 4.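

Placing 4-methoxybenzyl on the aromatic nitrogen moves the number in this assay much further than any change among the alkyl groups did, with a 19-fold higher number from compound 3 to compound 4 (1.28 log units; beyond the scatter) and a 23-fold higher number from compound 2 to compound 4 (1.36 log units; beyond the scatter) as the large steps. Even the hexyl group does better, as a 6.2-fold higher number from compound 1 to compound 4 (0.79 log units; beyond the scatter) shows for this ring-bearing group, so this position does not merely favour the branched chains over hexyl but also separates hexyl from 4-methoxybenzyl. No evidence at hand accounts for this loss.

Going by these compounds, it remains open whether the loss comes from the aromatic ring or from its methoxy group. A plain benzyl group and a cyclohexylmethyl group on this nitrogen would help to separate the two.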